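Methyl additions and solubility across two cores

The source may hold more compounds than are shown below. What is called first, only, known or untested is meant among the compounds shown, and "the series" means these compounds.

Compound 1 `CCCN(Cc1ccc(OCCN2C(=O)CCC2=O)c(C)c1)C(CC(=O)O)c1ccc(Cl)cc1` and compound 2 `CCCCN(Cc1ccc(OCCN2C(=O)CCC2=O)c(C)c1)C(CC(=O)O)c1ccc(Cl)cc1` share one core and differ by methyl in place of hydrogen on a saturated chain carbon, three bonds along the chain from an amine nitrogen. In a physicochemical assay for solubility, at pH 1.1 (on this read-out higher numbers stand for higher solubility and lower numbers for lower solubility), compound 1 gives 3000000 nM, and compound 2 gives 3000000 nM; the step reads no change at the digits printed from compound 1 to compound 2 (within the scatter). Compound 3 `Cc1cc(CN(CC2CCCC2)[C@@H](CC(=O)O)c2ccc(Cl)cc2)ccc1OCCN1C(=O)CCC1=O` is built on another core, and the difference between the two cores is not broken down here. In this assay compound 3 gives 3000000 nM, level with compound 1 and compound 2. Compound 4 `CCc1cc(CN(CC2CCCC2)[C@@H](CC(=O)O)c2ccc(Cl)cc2)ccc1OCCN1C(=O)CCC1=O` is not yet measured and differs from compound 3 by methyl in place of hydrogen on a saturated chain carbon bound to an aromatic carbon. This is the same kind of change as that between compound 1 and compound 2, though the place differs: there the methyl enters on a saturated chain carbon, three bonds along the chain from an amine nitrogen; here it enters on a saturated chain carbon bound to an aromatic carbon. Because the earlier step was no change at the digits printed from compound 1 to compound 2 (within the scatter), the step from compound 3 to compound 4 is expected to be no change at the digits printed from compound 3 to compound 4 (within the scatter). Compound 4 is therefore estimated at 3000000 nM, expected to fall between 1500000 nM and 3000000 nM.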

Compound 4, solubility: 3000000 nM
Compound 4: middle estimate and measured number agree at the digits printed; the measured number falls inside the stated range.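

In this assay the methyl in place of hydrogen gives no change at the digits printed from compound 3 to compound 4 (within the scatter) on one core and no change at the digits printed from compound 1 to compound 2 (within the scatter) on the other, so the two steps read alike. This shows that the change carried from one core to the other with no step beyond the scatter, although it enters at a different place on each core; two pairs do not show that this would hold at other places or on other cores. No measurement bears on why the steps read this way.

The compounds shown leave open whether a primary amine or a sulfonamide entering on the saturated chain carbon bound to an aromatic carbon would read the same.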